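The source may hold more compounds than are shown below. What is called first, only, known or untested is meant among the compounds shown, and "the series" means these compounds.

In a physicochemical assay for lipophilicity, read by HPLC, in phosphate buffer, measured as octanol-water partition, with stated times of 30 min and 48 h, at pH 7.4 (on this read-out higher numbers stand for higher lipophilicity and lower numbers for lower lipophilicity), compound 1 (`CCCC(CCC)C(=O)N(C)/N=N/c1ccc(C(N)=O)cc1`) gives 3.68 and compound 2 (`CCCC(CCC)C(=O)N(C)/N=N/c1ccc(Cl)cc1`) gives 4.62, while compound 3 (`CCCC(=O)N(C)/N=N/c1ccc(C#N)cc1`) gives 3.19 as the lowest of the three numbers. Compound 1 stands nearest to compound 3 and compound 2 furthest from it, both gaps lying beyond the usual scatter.

Compound 4 (`CCC(CC)C(=O)N(C)/N=N/c1ccc(C#N)cc1`) is still unmeasured. It departs from compound 3 by one change (ethyl in place of hydrogen on a saturated chain carbon bound to a carbonyl carbon and a saturated chain carbon), ethyl in place of hydrogen on a saturated chain carbon bound to a carbonyl carbon and a saturated chain carbon. Cut one bond further out, this reads propyl to pentan-3-yl.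

Among the measured compounds shown here, only one measured step is available (a number 0.94 log units higher from compound 1 to compound 2 (beyond the scatter)), chloro in place of carbamoyl on an aromatic carbon. It lies elsewhere in the structure, so it bears only indirectly and serves as a yardstick of size. For the measured compounds named here, no measured pair isolates a change in the chain on the carbonyl. Compound 3 gives 3.19. Compound 1 at 3.68 and compound 2 at 4.62 both carry a branched chain, and both of them stand higher than compound 3 even though their aromatic groups differ too. An upward step of similar, modest size beyond the scatter is therefore expected in this assay (a number 0.81 log units higher from compound 3 to compound 4 (beyond the scatter)). Compound 4 is estimated at 4 within an expected range (3.6 to 4.5).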

Compound 4, distribution coefficient: 3.76
Compound 4: middle estimate off by 0.24 log units, on the high side; measured number inside the range.
By their numbers in this assay, from the lowest: compound 3; then compounds 1 and 4 (each within the scatter of the next); then compound 2.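

Among the compounds shown here, with the nitrile held fixed, this pair isolates a change in the chain on the carbonyl for the first time: in this assay, ethyl in place of hydrogen on a saturated chain carbon bound to a carbonyl carbon and a saturated chain carbon gives a number 0.57 log units higher from compound 3 to compound 4 (beyond the scatter). For the compounds shown here, until now the only single-place step was on an aromatic carbon (a number 0.94 log units higher from compound 1 to compound 2 (beyond the scatter)), so the higher numbers of the branched compounds could not be separated from their different aromatic groups; this result shows that the chain position alone moves the read-out beyond the scatter, by a step also rated modest. No measurement shown gives a reason for this step.

The compounds shown leave open whether the step belongs to the branching or simply to the added carbons, which a straight pentyl chain on the same carbonyl would help to separate. They also leave open whether a similar step appears with carbamoyl or chloro on the aromatic carbon, and how the position responds to a chain carrying an amine or a carboxylic acid.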